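Moving and methylating the indole on compound 2

A few compounds are considered here, and "the series" means these few. Any claim that something is new, unique, unknown or untested is made for them only; others in the source may bear on it.

- compound 1 `CCOc1cc(-c2ccc3cc[nH]c3c2)cn2c(-c3cc(OC)c(OC)c(OC)c3)nnc12`: 272 nM
- compound 2 `CCOc1cc(-c2ccc3[nH]ccc3c2)cn2c(-c3cc(OC)c(OC)c(OC)c3)nnc12`: 166 nM
- compound 3 `COc1cc(-c2nnc3c(OC4CCC4)cc(-c4ccc5[nH]ccc5c4)cn23)cc(OC)c1OC`: 142 nM

In a functional assay on HeLa cells (Homo sapiens) for antiproliferative activity, read by MTT assay, with a stated time of 48 h (a lower number here means a stronger inhibitor, a higher number a weaker inhibitor), compound 2 gives 166 nM, and neither of the two measured steps that touch it goes beyond the scatter, so it cannot be clearly separated from either neighbour.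

Compound 4 `CCOc1cc(-c2ccc3ccn(C)c3c2)cn2c(-c3cc(OC)c(OC)c(OC)c3)nnc12` has not been measured yet. It keeps the shared core of compound 2 and changes one group: 1-methyl-1H-indol-6-yl in place of 1H-indol-5-yl on an aromatic carbon. Going by the values given here, this change combines two things: the indol-6-yl attachment also found in compound 1, and a 1-methyl group that no measured compound carries.

The attachment has a measured precedent in compound 1, with a 1.6-fold lower number from compound 1 to compound 2 (0.21 log units; within the scatter). The other measured step, a 1.2-fold lower number from compound 2 to compound 3 (0.07 log units; within the scatter), concerns the ethoxy group and says little here. Nothing measured gives the size of the methyl effect, so the range must stay wide. No step beyond the scatter is expected in this assay, with only a slight lean towards a higher number. The expected change is a 1.3-fold higher number from compound 2 to compound 4 (0.12 log units; within the scatter). Compound 4 is estimated at 220 nM, with an expected range of 70 nM to 700 nM.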

Compound 4, half-maximal inhibitory concentration: 240 nM
Estimate against measurement, compound 4: 1.1-fold (0.04 log units) below; the range from low to high includes it.
By their numbers in this assay, from the lowest: compounds 3, 2, 4 and 1 (each within the scatter of the next).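

Going by these compounds alone, the new result is the first to test a methyl on the indole nitrogen. In this assay there is a 1.1-fold lower number from compound 1 to compound 4 (0.05 log units; within the scatter) when methyl replaces that hydrogen, so with the indol-6-yl attachment, the change from 1 hydrogen-bond donor to 0 in the entering group moves the number no further than the scatter. The full swap on the shared core gives a 1.4-fold higher number from compound 2 to compound 4 (0.16 log units; within the scatter) and also stays within the scatter, so at this position 1-methyl-1H-indol-6-yl cannot be told apart from 1H-indol-5-yl, and nothing available here explains this result.

The compounds shown leave open whether a longer chain such as propyl on the indole nitrogen would behave like the methyl. They also leave open whether an amine or a carboxylic acid on the indole would produce a step beyond the scatter.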